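The source may report more compounds than this note shows. Statements on the series, on what has been measured and on what is new or still open speak of the compounds shown alone.

Among the compounds with values here, in a functional assay on HeLa cells (Homo sapiens) for inhibition (a higher number here means a weaker inhibitor, a lower number a stronger inhibitor), compound 2 `Cc1ccc(C(=O)CC(SCC(=O)O)C(=O)O)cc1` gives 17300 nM, the higher of the two numbers measured so far, whereas compound 1 `Cc1ccc(C(=O)CC(SCC(=O)O)C(=O)O)c(C)c1` gives 3830 nM. Compound 3 `Cc1ccc(C(=O)CC(SCC(=O)O)C(=O)O)c(Cl)c1` differs from compound 2 by chloro in place of hydrogen on an aromatic carbon, the aromatic carbon that in compound 1 bears the methyl. Within the data shown here, one measured step bears on this change: because a 4.5-fold higher number from compound 1 to compound 2 (0.65 log units; beyond the scatter) when that carbon was stripped to hydrogen, putting chloro back onto it is expected to lower the number in this assay, by about a 4.3-fold lower number from compound 2 to compound 3 (0.64 log units; beyond the scatter). For compound 3 the estimate is 4000 nM, with a range of 1500 nM to 12000 nM.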

Compound 3, half-maximal inhibitory concentration: 4730 nM
Beside the measured number, compound 3's estimate is 1.2-fold (0.07 log units) below it, and the stated range covers the measured number.
By their numbers in this assay, from the lowest: compounds 1 and 3 (each within the scatter of the next); then compound 2.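

In this assay chloro on this aromatic carbon gives a 3.7-fold lower number from compound 2 to compound 3 (0.56 log units; beyond the scatter) and so also lowers the number, which shows that the drop is not confined to methyl. Chloro and methyl cannot be told apart at this carbon, with a 1.2-fold higher number from compound 1 to compound 3 (0.09 log units; within the scatter) in the step between them. Nothing available accounts for this shared effect of the two groups.

Open, from the compounds shown here alone, is how bromo, methoxy, trifluoromethyl or an amine would read at this carbon. Also open, going by these compounds, is whether the two acid-bearing chains of the shared core tolerate an amide or a longer chain.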